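The compounds below may be only part of what the source reports. "The series", "measured", "known", "first", "only" and "open" are said of these compounds alone.

Three compounds of one shared core have been measured:

Compound 1, `CCCCCCCCCCCC(=O)Nc1cc2c(cc1F)c(=O)c(C(=O)OCC)cn2CC`, gives 9800 nM in a functional assay on SK-OV-3 cells (Homo sapiens) for cytotoxicity, read by MTT assay; on this read-out lower numbers stand for stronger inhibition and higher numbers for weaker inhibition.
Compound 2, `CCCCCCCCCCCCCCCC(=O)Nc1cc2c(cc1F)c(=O)c(C(=O)OCC)cn2CC`, gives 17800 nM in this assay.
Compound 3, `CCCCCCCCCCCCCC(=O)Nc1cc2c(cc1F)c(=O)c(C(=O)OCC)cn2CC`, gives 8200 nM in this assay.

The core of compound 3 differs from the core of compound 1 by ethyl in place of hydrogen on a saturated chain carbon, ten or more bonds along the chain from a carbonyl carbon. Lengthening the chain from compound 1 to compound 2 is the change (butyl in place of hydrogen on a saturated chain carbon, ten or more bonds along the chain from a carbonyl carbon), and it gave a 1.8-fold higher number from compound 1 to compound 2 (0.26 log units; within the scatter). The unmeasured compound 4, `CCCCCCCCCCCCCCCCCC(=O)Nc1cc2c(cc1F)c(=O)c(C(=O)OCC)cn2CC`, carries the same change made on compound 3: butyl in place of hydrogen on a saturated chain carbon, ten or more bonds along the chain from a carbonyl carbon, at the same place in the same words. Because the earlier step of a 1.8-fold higher number from compound 1 to compound 2 (0.26 log units; within the scatter) was small, a similar step is expected here, so compound 4 is estimated to show a 1.8-fold higher number from compound 3 to compound 4 (0.26 log units; within the scatter). Compound 4 is therefore expected to give about 15000 nM in this assay, most likely between 7500 nM and 32000 nM.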

Compound 4, half-maximal inhibitory concentration in the SK-OV-3 assay: 35200 nM
The estimate for compound 4 lay 2.3-fold (0.37 log units) below the measured number; the whole stated range lies below it.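

In the SK-OV-3 assay, compound 4 gives 35200 nM, and the new steps are a 4.3-fold higher number from compound 3 to compound 4 (0.63 log units; beyond the scatter), a 2.0-fold higher number from compound 2 to compound 4 (0.30 log units; within the scatter) and a 3.6-fold higher number from compound 1 to compound 4 (0.56 log units; beyond the scatter). Butyl in place of hydrogen carries from one core to the other with no gap beyond the scatter: the same change on two cores in the SK-OV-3 assay, a 1.8-fold higher number (0.26 log units; within the scatter) from compound 1 to compound 2 and a 4.3-fold higher number (0.63 log units; beyond the scatter) from compound 3 to compound 4, 2.4-fold (0.37 log units) apart, within the scatter of two such steps Ethyl in place of hydrogen carries over in the same way, although two pairs of compounds cannot show that a step keeps one exact size on any other core in this series: the same change on two cores in the SK-OV-3 assay, a 1.2-fold lower number (0.08 log units; within the scatter) from compound 1 to compound 3 and a 2.0-fold higher number (0.30 log units; within the scatter) from compound 2 to compound 4, 2.4-fold (0.37 log units) apart, within the scatter of two such steps In a physicochemical assay (on this read-out lower numbers stand for an effect already at smaller amounts and higher numbers for an effect only at larger amounts of compound), compound 3 gives 286 ug/mL and compound 4 gives 799 ug/mL.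

All the compounds shown carry a plain saturated chain on the same amide. Going by these compounds, whether a longer chain, a branched chain or a chain ending in an amine would follow these steps remains open.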